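This account rests on a few compounds, and the source may have more. Where it says the series, first, only, none or still open, it means among the compounds named here.

Compound 1 `COc1ccc(C(=O)/C=C/c2ccc3ccccc3n2)c2c1C=CC(C)(C)O2` gives 2350 nM in a functional assay on SK-OV-3 cells (Homo sapiens) for antiproliferative activity, read by MTT assay, with a stated time of 24 h; on this read-out lower numbers stand for stronger inhibition and higher numbers for weaker inhibition.
Compound 2 `COc1ccc(C(=O)/C=C/c2ccco2)c2c1C=CC(C)(C)O2` gives > 10000 nM in this assay, which is a limit of the assay and not a number.

The two values leave compound 2 without a fixed place: in this assay it sits at the limit of > 10000 nM in this assay, at which 1 of the 2 values shown sits, so only the limit is known for it, while compound 1 stands at a measured number within the range of the assay.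

Compound 3 `COc1ccc(C(=O)/C=C/c2cc(Cl)ccc2O)c2c1C=CC(C)(C)O2` has not yet been measured in this assay. It differs from compound 2 in one place: 5-chloro-2-hydroxyphenyl in place of furan-2-yl on a double-bonded chain carbon bound to a double-bonded chain carbon. Among the compounds with values here, no step between two measured compounds is known that would show what such a change does in this assay; the move from a five-membered aromatic ring with one hetero atom to a six-membered aromatic ring of carbon only, carrying one hydrogen-bond donor, is untested.

Compound 3 is expected to come in around 3500 nM, with a range from 1000 nM to 10000 nM. Because compound 2 sits at the limit of > 10000 nM in this assay, at which 1 of the 2 values shown sits, the expected step of an at least 2.8-fold lower number from compound 2 to compound 3 (0.45 log units; beyond the scatter) is toward a lower number, though its true size cannot be fixed from a limit.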

Compound 3, half-maximal inhibitory concentration: 6270 nM
For compound 3 the middle estimate is 1.8-fold (0.25 log units) below the measured one; the range from low to high includes it.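

In this assay, the place on a double-bonded chain carbon bound to a double-bonded chain carbon now carries a group that gives a measured number: with 5-chloro-2-hydroxyphenyl in place of furan-2-yl, compound 3 falls within the range of the assay, which compound 2 does not. The change gives an at least 1.5-fold lower number from compound 2 to compound 3 (0.20 log units; that floor lies within the scatter), so the data show this six-membered aromatic ring of carbon only to be compatible with a measurable antiproliferative effect, but they set only a floor on the step. Its true size stays unknown because one end of the step is not a number: the limit of > 10000 nM in this assay, at which 1 of the 3 values shown sits.

The change swaps the ring and brings in the chlorine and the hydroxyl group all at once, so the compounds shown do not tell which of these accounts for the step. An unsubstituted phenyl, a 2-hydroxyphenyl or a 3-chlorophenyl at this place would separate these parts, and a 5-chloro-2-aminophenyl would show whether the hydroxyl group can give way to an amine.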